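The source may report more compounds than this note shows. Statements on the series, on what has been measured and on what is new or still open speak of the compounds shown alone.

In a functional assay on HL-60 cells (Homo sapiens) for antiproliferative activity, read by MTT assay, with a stated time of 72 h (a higher number here means a weaker inhibitor, a lower number a stronger inhibitor), three compounds have been measured.

- Compound 1 `NC1=NC2(CCOCC2)N(OCCCOc2ccc(Cl)cc2)C(N)=N1` gives 330 nM
- Compound 2 `NC1=NC2(CCOCC2)N(OCCCOc2ccccc2Cl)C(N)=N1` gives 660 nM
- Compound 3 `NC1=NC2(CCOCC2)N(OCCCOc2ccc(Cl)cc2Cl)C(N)=N1` gives 330 nM

Compound 3 sits level with compound 1 and within the scatter of compound 2, so none of the three stands apart. Compound 4 `NC1=NC2(CCOCC2)N(OCCCOc2cc(Cl)c(Cl)cc2Cl)C(N)=N1` carries one more change, (chloro in place of hydrogen on an aromatic carbon), which takes 2,4-dichlorophenyl to 2,4,5-trichlorophenyl. Two measured steps made the same kind of swap, chloro in place of hydrogen on an aromatic carbon: no change at the digits printed from compound 1 to compound 3 (within the scatter) and a 2.0-fold lower number from compound 2 to compound 3 (0.30 log units; within the scatter), both within the scatter. Neither put a chloro at this place on the ring, so the evidence is thin, and in this assay no step beyond the scatter is expected. The expected step is a 1.1-fold lower number from compound 3 to compound 4 (0.04 log units; within the scatter) at most a small one. For compound 4 the estimate is 300 nM, with an expected range from 110 nM to 800 nM in repeat measurements.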

Compound 4, half-maximal inhibitory concentration: 2360 nM
Estimate against measurement, compound 4: 7.9-fold (0.90 log units) below; the whole stated range lies below it.
By their numbers in this assay, from the lowest: compounds 1, 3 and 2 (each within the scatter of the next); then compound 4.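

In this assay, the chloro that turns 2,4-dichlorophenyl into 2,4,5-trichlorophenyl gives a 7.2-fold higher number from compound 3 to compound 4 (0.85 log units; beyond the scatter), so adding a chloro at this place weakens the compound, while the earlier chloro additions stayed within the scatter. The loss also shows against the two compounds with a single chloro, as a 3.6-fold higher number from compound 2 to compound 4 (0.55 log units; beyond the scatter) and a 7.2-fold higher number from compound 1 to compound 4 (0.85 log units; beyond the scatter). Nothing measured here offers a reason for it.

As far as these compounds go, whether the loss belongs to chloro itself or to any group at this place remains open. A fluoro or a methoxy there would help to separate the two.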